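The source may report more compounds than this note shows. Statements on the series, on what has been measured and on what is new or still open speak of the compounds shown alone.

Measured compounds:
- compound 1 `Cn1c(-c2ccccc2C(F)(F)F)nnc1C12CCC(CCS(C)(=O)=O)(CC1)CC2`: in an assay on CHO-K1 cells for inhibition of 11-beta-hydroxysteroid dehydrogenase type 2 (Homo sapiens), read by scintillation proximity assay (a higher number here means a weaker inhibitor, a lower number a stronger inhibitor), compound 1 gives only a limit, > 4000 nM.
- compound 2 `Cn1c(-c2ccccc2C(F)(F)F)nnc1C12CCC(CNS(C)(=O)=O)(CC1)CC2`: in this assay compound 2 gives only a limit, > 4000 nM.
- compound 3 `CC(C)S(=O)(=O)CCC12CCC(c3nnc(-c4ccccc4C(F)(F)F)n3C)(CC1)CC2`: in this assay compound 3 gives only a limit, > 4000 nM.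

Compound 3 thus stands at the limit of this assay, as do both others, which is all that the limit of > 4000 nM in this assay, at which 3 of the 3 values shown sit, records. The three pairwise steps, a step that the two limits leave unreadable from compound 1 to compound 2, a step that the two limits leave unreadable from compound 1 to compound 3 and a step that the two limits leave unreadable from compound 2 to compound 3, are unreadable from limits alone. Compound 4 `CC(O)CCCC12CCC(c3nnc(-c4ccccc4C(F)(F)F)n3C)(CC1)CC2` differs from compound 3 by 2-hydroxypropyl in place of isopropylsulfonyl on a saturated chain carbon, two bonds along the chain from a saturated ring carbon. Going by the values given here, no measured step bears readably on this change. The step that the limit leaves unreadable from compound 3 to compound 4 is therefore expected to stay near the limit. Compound 4 is expected at 6000 nM, with a range from 1000 nM to 40000 nM.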

Compound 4, half-maximal inhibitory concentration: > 1000 nM
Compound 4: no number, only a limit (the forecaster's own chance of this, stated with the estimate: 70%); the middle value lies beyond the limit too.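

Compound 4 gives only a limit in this assay, as do compound 1, compound 2 and compound 3, so no step among these compounds can be read. The compounds shown leave open whether any change on this chain alters inhibition.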